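A Nitrophenyl Replaces the Carbamate on the Ring Nitrogen

The source may report more compounds than this note shows. Statements on the series, on what has been measured and on what is new or still open speak of the compounds shown alone.

Three analogues of one core have been measured. Compound 1 `O=C(CN1CCN(c2ccccc2F)CC1)Nc1ccc(C(=O)/C=C/c2cn(Cc3ccc(Br)cc3)nn2)cc1` gives 9120 nM in a functional assay on HeLa cells (Homo sapiens) for inhibition, read by MTT assay; a lower number here means a stronger inhibitor, a higher number a weaker inhibitor. Compound 2 `O=C(CN1CCN(c2ccccc2)CC1)Nc1ccc(C(=O)/C=C/c2cn(Cc3ccc(Br)cc3)nn2)cc1` gives 79700 nM in this assay, and the step of an 8.7-fold higher number from compound 1 to compound 2 (0.94 log units; beyond the scatter) separates the two. Compound 3 `CC(C)(C)OC(=O)N1CCN(CC(=O)Nc2ccc(C(=O)/C=C/c3cn(Cc4ccc(Br)cc4)nn3)cc2)CC1` gives 18900 nM in this assay; it stands second highest of the three numbers, nearest to compound 1 through the step of a 2.1-fold higher number from compound 1 to compound 3 (0.32 log units; beyond the scatter) and furthest from compound 2 through the step of a 4.2-fold lower number from compound 2 to compound 3 (0.62 log units; beyond the scatter).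

Compound 4 `O=C(CN1CCN(c2ccc([N+](=O)[O-])cc2)CC1)Nc1ccc(C(=O)/C=C/c2cn(Cc3ccc(Br)cc3)nn2)cc1` is not yet measured. Its change from compound 3 is 4-nitrophenyl in place of tert-butoxycarbonyl on an amine nitrogen in a ring. Going by the values given here, the steps that bear on it are the two in which the tert-butoxycarbonyl group is exchanged for an aromatic ring on that nitrogen: one went modestly down, the other modestly up, so an aryl group on this nitrogen has pulled the number in either direction. Compound 4 is therefore expected to move only modestly, in a direction that cannot be fixed, so the step of a 1.1-fold higher number from compound 3 to compound 4 (0.02 log units; within the scatter) is estimated as small. Compound 4 is expected to give about 20000 nM in this assay, within the range 5000 nM to 80000 nM.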

Compound 4, half-maximal inhibitory concentration: 26600 nM
Compound 4: middle estimate off by 1.3-fold (0.12 log units), on the low side; measured number inside the range.
By their numbers in this assay, from the lowest: compound 1; then compounds 3 and 4 (each within the scatter of the next); then compound 2.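

In this assay, 4-nitrophenyl in place of tert-butoxycarbonyl on the ring nitrogen gives a 1.4-fold higher number from compound 3 to compound 4 (0.15 log units; within the scatter), so at this position these two groups are not told apart, despite the aromatic ring that enters. What the aryl ring carries does count: nitro in place of hydrogen gives a 3.0-fold lower number from compound 2 to compound 4 (0.48 log units; beyond the scatter), which makes nitro the second group, after fluoro in compound 1, to give a lower number than the unsubstituted phenyl of compound 2, while the exchange of aryl groups gives a 2.9-fold higher number from compound 1 to compound 4 (0.46 log units; beyond the scatter). No evidence is at hand to explain these differences.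

The compounds shown leave open whether the gap between the 2-fluorophenyl and 4-nitrophenyl groups follows the substituent or its place on the ring, as the two change together in this pair. As far as these compounds go, how an amine or a carboxylic acid on that ring would read also remains open.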